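This account rests on a few compounds, and the source may have more. Where it says the series, first, only, none or still open, it means among the compounds named here.

In a functional assay on HeLa cells (Homo sapiens) for antiproliferative activity, with a stated time of 5 days (a higher number here means a weaker inhibitor, a lower number a stronger inhibitor), compound 3 `O=C1C=CC2(C=C1)OCC(=O)N2c1nc(-c2ccc(F)c3ccccc23)nn1-c1ccccc1` gives 200 nM and sits level with compound 1 `COc1ccc(-n2nc(-c3ccc4ccccc4c3)nc2N2C(=O)COC23C=CC(=O)C=C3)cc1` at 200 nM while compound 2 `O=C1C=CC2(C=C1)OCC(=O)N2c1nc(-c2ccc3ncccc3c2)nn1-c1ccccc1` at 110 nM lies within the scatter of both. Compound 4 `O=C1C=CC2(C=C1)OCC(=O)N2c1nc(-c2ccc3ccccc3c2)nn1-c1ccccc1` has naphthalen-2-yl in place of 4-fluoronaphthalen-1-yl, a change counted as naphthalen-2-yl in place of 4-fluoronaphthalen-1-yl on an aromatic carbon on an aromatic carbon of a five-membered aromatic ring with 3 nitrogen. Among the compounds with values here, the one measured step at this place runs a 1.8-fold higher number from compound 2 to compound 3 (0.26 log units; within the scatter) and stays small. Compound 1 also bears naphthalen-2-yl and gives 200 nM but differs from compound 4 elsewhere. No step beyond the scatter is therefore expected in this assay from this change. The estimated move is a 1.3-fold lower number from compound 3 to compound 4 (0.12 log units; within the scatter) and remains within the scatter. Compound 4 is expected at 150 nM with 70 nM to 320 nM as the estimated range.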

Compound 4, half-maximal inhibitory concentration: 120 nM
The estimate for compound 4 lay 1.3-fold (0.10 log units) above the measured number, within the range that was stated.
By their numbers in this assay, from the lowest: compounds 2, 4, 1 and 3 (each within the scatter of the next).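

In this assay the group on the aromatic carbon of the five-membered aromatic ring can now be compared directly: naphthalen-2-yl in place of 4-fluoronaphthalen-1-yl runs a 1.7-fold lower number from compound 3 to compound 4 (0.22 log units; within the scatter) and naphthalen-2-yl in place of quinolin-6-yl runs a 1.1-fold higher number from compound 2 to compound 4 (0.04 log units; within the scatter) with neither exchange leaving the scatter. Hydrogen in place of methoxy on the phenyl group runs a 1.7-fold lower number from compound 1 to compound 4 (0.22 log units; within the scatter) and so adds a second place where the step stays small.

On these data alone, whether an amine or a carboxylic acid on the phenyl group would give a step beyond the scatter stays open. No measurement at hand bears on a cause for these steps.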